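The source may report more compounds than this note shows. Statements on the series, on what has been measured and on what is new or still open speak of the compounds shown alone.

Working notes on the series. In a functional assay on HCT-116 cells (Homo sapiens) for cytotoxicity, read by MTT assay, with a stated time of 72 h (a higher number here means a weaker inhibitor, a lower number a stronger inhibitor), compound 1 `COc1ccc(-c2cc(/N=C3/NC(=O)CS3)cs2)cc1` gives > 50000 nM, which is a limit of the assay and not a number. Compound 2 `COc1cccc(N2C(=O)CS/C2=N\c2csc(-c3ccccc3)c2)c1` has the entry "not determined" (no result reported). Among the measured compounds shown here, compound 3 `COc1cccc(N2C(=O)CS/C2=N\c2csc(-c3ccc(C)cc3)c2)c1` gives 41000 nM, the only actual number so far, so it cannot yet be ranked against a measured neighbour. Compound 4 `COc1ccc(-c2cc(/N=C3\SCC(=O)N3c3cccc(OC)c3)cs2)cc1` differs from compound 3 by one change, methoxy in place of methyl on an aromatic carbon, turning 4-methylphenyl into 4-methoxyphenyl. For the measured compounds named here, no measured step bears on this change, so with compound 3 at 41000 nM as the sole anchor, no shift beyond the scatter is expected in this assay, in either direction. For compound 4 the estimated value is 40000 nM, with an expected range of 18000 nM to 50000 nM.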

Compound 4, half-maximal inhibitory concentration: 2700 nM
Beside the measured number, compound 4's estimate is 15-fold (1.17 log units) above it; the measured number lies below the stated range.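

Swapping 4-methylphenyl for 4-methoxyphenyl gives the series its first readable step in this assay, and that step is large: a 15-fold lower number from compound 3 to compound 4 (1.18 log units; beyond the scatter). Adding 3-methoxyphenyl on the amide-type nitrogen in the ring also goes with an at least 18-fold lower number from compound 1 to compound 4 (1.26 log units; beyond the scatter). The entry for compound 1 is a limit of the assay, not a number: the limit of > 50000 nM in this assay, at which 1 of the 4 values shown sits.

Going by these compounds, whether an ethoxy group or an amine in the same place would match methoxy stays open, as does whether a carboxylic acid could stand in place of the 3-methoxyphenyl's methoxy. Steps involving compound 2 cannot be read.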